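The compounds below may be only part of what the source reports. "The series", "measured", "known", "first", "only" and "open" are said of these compounds alone.

Compound 1 `C=CCc1cc(OC)c(OC(C)C(OCCOCCCC)c2ccc(O)c(OC)c2)c(OC)c1`: 153 nM
Compound 2 `C=CCc1cc(OC)c(OC(C)C(O[C@H]2C[C@@H](C)CC[C@@H]2C(C)C)c2ccc(O)c(OC)c2)c(OC)c1`: 11 nM

Compound 2 gives the lowest of these two numbers in an assay on HEK293 cells for agonist activity at transient receptor potential cation channel subfamily M member 8 (Homo sapiens), read by fluorescence and calcium flux, with a stated time of 5 min; on this read-out lower numbers stand for an effect already at smaller amounts and higher numbers for an effect only at larger amounts of compound; its nearest neighbour is compound 1, separated by a 14-fold lower number from compound 1 to compound 2 (1.14 log units; beyond the scatter). Compound 3 `C=CCc1cc(OC)c(OC(C)C(OC2CCCCC2)c2ccc(O)c(OC)c2)c(OC)c1` differs from compound 2 in that (a group of 6 heavy atoms (6 carbon; one six-membered non-aromatic ring of carbon only) in place of a group of 10 heavy atoms (10 carbon; one six-membered non-aromatic ring of carbon only), on an oxygen on a saturated carbon). Among the measured compounds shown here, only one measured step bears on this change: a 14-fold lower number from compound 1 to compound 2 (1.14 log units; beyond the scatter), where a ring took the place of a chain and the number fell greatly. Compound 3 keeps a ring at the same place, but a smaller one than in compound 2, so its number is expected to sit between the two measured values. The expected step is a 4.5-fold higher number from compound 2 to compound 3 (0.66 log units; beyond the scatter), a moderate rise. Compound 3 is estimated at 50 nM, with a range from 20 nM to 150 nM.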

Compound 3, half-maximal effective concentration: 54 nM
Compound 3: the middle estimate sits 1.1-fold (0.03 log units) below what was measured; the range from low to high includes it.
By their numbers in this assay, from the lowest: compound 2; then compound 3; then compound 1.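

Cyclohexyl on this oxygen shows that a plain ring already gives a lower number than the 2-butoxyethyl chain (a 2.8-fold lower number from compound 1 to compound 3 (0.45 log units; beyond the scatter)), yet it does not reach the number of compound 2 (a 4.9-fold higher number from compound 2 to compound 3 (0.69 log units; beyond the scatter)). So the ring accounts for only part of the fall, and the rest goes with the larger group of compound 2. Nothing available explains this order. The larger group differs from cyclohexyl in both its extra carbons and its defined stereocentres, and these compounds cannot separate the two. Where a cyclopentyl or phenyl ring on this oxygen would fall remains open.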